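The source may hold more compounds than are shown below. What is called first, only, known or untested is meant among the compounds shown, and "the series" means these compounds.

Of the compounds shown here, three of a shared core have been measured in an assay on microsomes from intestine for inhibition of acyl-CoA:cholesterol acyltransferase (Oryctolagus cuniculus); on this read-out lower numbers stand for stronger inhibition and higher numbers for weaker inhibition. Compound 1 (`Cc1cc(C)c(NC(=O)N(Cc2cccc(-c3nn[nH]n3)c2)C2CCCCCC2)c(C)c1`) gives > 1000 nM, which is a limit of the assay rather than a number; that reading is the limit of > 1000 nM in this assay, at which 1 of the 3 values shown sits. Compound 2 (`O=C(Nc1c(F)cc(F)cc1F)N(Cc1cccc(-c2cc[nH]n2)c1)C1CCCCCC1`) gives 22 nM in this assay. Compound 3 (`Cc1cc(C)c(NC(=O)N(Cc2cccc(-c3cc[nH]n3)c2)C2CCCCC2)c(C)c1`) gives 39 nM in this assay, and the gap between compound 3 and compound 2 lies within the usual scatter, so the two cannot be told apart on these numbers.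

Compound 4 (`Cc1cc(C)c(NC(=O)N(Cc2cccc(-c3cc[nH]n3)c2)C2CCCCCC2)c(C)c1`) is the next compound. It differs from compound 3 in one place: cycloheptyl in place of cyclohexyl on an amide-type nitrogen. Within the data shown here, no measured pair shows this exact change on its own, so there is no step to lean on. Compound 2, which carries the same cycloheptyl group, gives 22 nM in this assay, and that is the only hint available. The step from compound 3 to compound 4 is expected to be a 1.3-fold lower number from compound 3 to compound 4 (0.11 log units; within the scatter), nothing beyond the scatter. Compound 4 is therefore estimated at 30 nM in this assay, within a range from 10 nM to 100 nM.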

Compound 4, half-maximal inhibitory concentration: 65 nM
Compound 4: middle estimate off by 2.2-fold (0.34 log units), on the low side; low and high end bracket the measured number.
By their numbers in this assay, from the lowest: compounds 2, 3 and 4 (each within the scatter of the next, the first and the last beyond it). At a limit, above all of these: compound 1.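

In this assay, the size of the ring on the amide-type nitrogen makes no readable difference: a 1.7-fold higher number from compound 3 to compound 4 (0.22 log units; within the scatter), so cycloheptyl and cyclohexyl cannot be told apart at this position. The other two single changes do show up, with 2,4,6-trimethylphenyl in place of 2,4,6-trifluorophenyl giving a 3.0-fold higher number from compound 2 to compound 4 (0.47 log units; beyond the scatter), and 1H-pyrazol-3-yl in place of 2H-tetrazol-5-yl on an aromatic carbon giving an at least 15-fold lower number from compound 1 to compound 4 (1.18 log units; beyond the scatter). Compound 1 gives a limit of the assay rather than a number, so that last step has no exact size: the limit of > 1000 nM in this assay, at which 1 of the 4 values shown sits.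

Still open, from the compounds shown here alone, is how a cyclopentyl ring or an open chain such as hexyl would behave on the amide-type nitrogen. Going by these compounds, it is equally open how a carboxylic acid would compare with the 1H-pyrazol-3-yl group on the aromatic carbon.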